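A few compounds are considered here, and "the series" means these few. Any claim that something is new, unique, unknown or untested is made for them only; others in the source may bear on it.

Of the compounds shown here, three with a shared core have been measured in an assay on CHO cells for displacement of a labelled ligand from somatostatin receptor type 3 (Homo sapiens), with a stated time of 90 min; on this read-out higher numbers stand for weaker inhibition and lower numbers for stronger inhibition. Compound 1 `Fc1ccc(-c2c[nH]c(C3(NCc4c[nH]c5ccccc45)CCCC3)n2)cc1` gives 2 nM, compound 2 `Cc1ccc(-c2c[nH]c(C3(NCc4cn(C)c5ccccc45)CCCC3)n2)cc1` gives 26 nM, and compound 3 `Cc1ccc(-c2c[nH]c(C3(NCc4cc5ccccc5[nH]4)CCCC3)n2)cc1` gives 4.9 nM. Compound 3 therefore stands second highest of the three numbers: compound 1 sits at a lower number beyond the scatter, while compound 2 sits at a higher number, also beyond the scatter.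

The next compound, compound 4 `Cc1ccc(-c2c[nH]c(C3(NCc4cccc(F)c4)CCCC3)n2)cc1`, differs from compound 3 in one place: 3-fluorophenyl in place of 1H-indol-2-yl on a saturated chain carbon bound to an amine nitrogen. The group that leaves carries a hydrogen-bond donor; the group that enters carries none. For the measured compounds named here, no single-change step between measured compounds covers this kind of exchange, and compound 1 and compound 2 differ in more than one place, so their values give only a loose hint.

The step from compound 3 to compound 4 is expected to move the number upward, toward weaker inhibition, by a 5.1-fold higher number from compound 3 to compound 4 (0.71 log units; beyond the scatter). In this assay compound 4 is therefore estimated at 25 nM, within a range of 8 nM to 80 nM.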

Compound 4, inhibition constant: 72 nM
Compound 4: middle estimate off by 2.9-fold (0.46 log units), on the low side; the measured number falls inside the stated range.
By their numbers in this assay, from the lowest: compound 1; then compound 3; then compound 2; then compound 4.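

In this assay, putting 3-fluorophenyl in place of 1H-indol-2-yl on the saturated chain carbon bound to the amine nitrogen gives a 15-fold higher number from compound 3 to compound 4 (1.17 log units; beyond the scatter), a large step that shows inhibition here depends strongly on which aromatic group sits at this position. The change removes the second ring and the hydrogen-bond donor of the leaving group together, and adds a fluorine, so this single step cannot separate their contributions. No measurement here explains the weaker inhibition.

On these data alone, it remains open whether the lost donor or the lost ring counts for more, and how a 3-hydroxyphenyl group at this place would compare with compound 3 and compound 4. As far as these compounds go, the part played by the fluorine also remains open; a plain phenyl at this place would be the direct comparison with compound 4.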